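From a 2-methoxybenzyl amine to a 4-methoxyphenyl amine

This account rests on a few compounds, and the source may have more. Where it says the series, first, only, none or still open, it means among the compounds named here.

Of the compounds shown here, two built on one shared core have been tested in a functional assay on MDA-MB-231 cells (Homo sapiens) for inhibition, read by CCK-8 assay, with a stated time of 48 h; on this read-out lower numbers stand for stronger inhibition of growth and higher numbers for weaker inhibition of growth. Compound 1 `Cc1ccc(CNc2nc(Nc3ccc(N4CCN(C)CC4)cn3)ncc2Cl)cc1` gives 18600 nM in this assay. Compound 2 `COc1ccccc1CNc1nc(Nc2ccc(N3CCN(C)CC3)cn2)ncc1Cl` gives 29300 nM in this assay, and it stands alongside compound 1, since the step of a 1.6-fold higher number from compound 1 to compound 2 (0.20 log units; within the scatter) lies within the scatter. Compound 3 `COc1ccc(Nc2nc(Nc3ccc(N4CCN(C)CC4)cn3)ncc2Cl)cc1` has not yet been measured. It differs from compound 2 in one place: 4-methoxyphenyl in place of 2-methoxybenzyl on a nitrogen on an aromatic ring. Among the compounds with values here, the only measured step exchanged one substituted ring for another while keeping the saturated chain carbon, and that step was small. Within the data shown here, no measured step removes the saturated carbon between the nitrogen and the ring, so the change leading to compound 3 has no direct precedent here. With nothing pointing either way, the expected step of a 1.2-fold lower number from compound 2 to compound 3 (0.07 log units; within the scatter) is taken as no larger than the scatter. Compound 3 is therefore estimated at 25000 nM in this assay, with a range from 6000 nM to 100000 nM.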

Compound 3, concentration for 50% growth inhibition: 8020 nM
The estimate for compound 3 lay 3.1-fold (0.49 log units) above the measured number, within the range that was stated.
By their numbers in this assay, from the lowest: compound 3; then compounds 1 and 2 (each within the scatter of the next).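

In this assay, this position proves able to shift the number beyond the scatter, which the swap between the two benzyl groups did not show: 4-methoxyphenyl on the nitrogen gives a 3.7-fold lower number from compound 2 to compound 3 (0.56 log units; beyond the scatter) and a 2.3-fold lower number from compound 1 to compound 3 (0.37 log units; beyond the scatter). Both steps are modest, but together they make compound 3 the lowest of the three. Compound 3 is also the only one of the three without a saturated chain carbon on that nitrogen, although the step from compound 2 also moves the methoxy group from the 2 to the 4 position on the ring. No measurement shown here explains the shift.

On these data alone, it remains open whether the lower number follows from losing the saturated carbon, from the methoxy placement, or from both. A 4-methoxybenzyl or 2-methoxyphenyl group on the same nitrogen would help separate these, while a longer chain such as 2-phenylethyl would test the other direction.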